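This account rests on a few compounds, and the source may have more. Where it says the series, first, only, none or still open, it means among the compounds named here.

In an ADME assay on HEK293 cells (Homo sapiens) for cytotoxicity, read by MTT assay, with a stated time of 36 h (on this read-out lower numbers stand for stronger inhibition and higher numbers for weaker inhibition), compound 1 `O=C(c1ccc2c(c1)OCCO2)C1CCN(Cc2coc(-c3ccc(Cl)cc3)n2)CC1` gives only a limit, > 150 ug/mL. Compound 2 `O=C(c1ccc2c(c1)OCCO2)C1CCN(Cc2coc(-c3ccc(Br)cc3)n2)CC1` likewise gives only a limit, > 150 ug/mL. Compound 3 `O=C(c1ccc2c(c1)OCCO2)C1CCN(Cc2coc(-c3cccc(F)c3)n2)CC1` also gives only a limit, > 150 ug/mL. So compound 3 stands where every value shown stands, namely at the limit of > 150 ug/mL in this assay, at which 3 of the 3 values shown sit, and no order among the three compounds can be read. Compound 4 `CC(C)(C)c1ccc(-c2nc(CN3CCC(C(=O)c4ccc5c(c4)OCCO5)CC3)co2)cc1` differs from compound 3 by 4-(tert-butyl)phenyl in place of 3-fluorophenyl on an aromatic carbon. The measured steps that bear on this change are all hidden by the limits: a step that the two limits leave unreadable from compound 1 to compound 2, a step that the two limits leave unreadable from compound 1 to compound 3 and a step that the two limits leave unreadable from compound 2 to compound 3. Nothing therefore points to a step of any readable size or direction in this assay. Compound 4 is expected to sit near the same limit, with an estimated step of a number no higher from compound 3 to compound 4 (the limit leaves the size open). Compound 4 is thus estimated at 150 ug/mL, within 60 ug/mL to 300 ug/mL.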

Compound 4, half-maximal inhibitory concentration: > 150 ug/mL
Compound 4 gave a limit, no number; the forecaster's own chance of this, stated with the estimate: 65%; the middle value lies on the limit itself.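

Among these compounds, compound 4 also gives only a limit, so no step from compound 1, compound 2 or compound 3 to compound 4 can be read: the limit of > 150 ug/mL in this assay, at which 4 of the 4 values shown sit. The compounds shown leave open the actual value of each of the four, and so whether the groups that differ among them change the read-out at all.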